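Swapping one fluoro for hydrogen on compound 3

The source may report more compounds than this note shows. Statements on the series, on what has been measured and on what is new or still open speak of the compounds shown alone.

Measured so far in a functional assay on CCRF-CEM cells (Homo sapiens) for cytotoxicity, in the presence of a further agent that is not named here; on this read-out lower numbers stand for stronger inhibition and higher numbers for weaker inhibition
Compound 1 (`COC(=O)c1ccc(CN(CCCc2c(N)nc(N)nc2O)c2cc(F)cc(F)c2[N+](=O)[O-])cc1`): > 100000 nM (a limit)
Compound 2 (`CC(C)(C)OC(=O)CCC(Nc1ccc(CN(CCCc2c(N)nc(N)nc2O)c2cc(F)c([N+](=O)[O-])cc2[N+](=O)[O-])cc1)C(=O)OC(C)(C)C`): 1800 nM
Compound 3 (`CC(C)(C)OC(=O)CCC(Nc1ccc(CN(CCCc2c(N)nc(N)nc2O)c2cc(F)cc(F)c2[N+](=O)[O-])cc1)C(=O)OC(C)(C)C`): 7700 nM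

The entry for compound 1, > 100000 nM, is a limit of the assay and not a number. Of the two true numbers, compound 3 stands higher at 7700 nM, meaning weaker inhibition, while compound 2 lies lower at 1800 nM, a gap beyond the usual scatter of repeats.

Compared with compound 3, compound 4 (`CC(C)(C)OC(=O)CCC(Nc1ccc(CN(CCCc2c(N)nc(N)nc2O)c2cc(F)ccc2[N+](=O)[O-])cc1)C(=O)OC(C)(C)C`) carries hydrogen in place of fluoro on an aromatic carbon, ortho to a nitro group. This turns 3,5-difluoro-2-nitrophenyl into 5-fluoro-2-nitrophenyl.

Within the data shown here, no measured pair shows this change alone, so any forecast in this assay is uncertain. A modest move towards weaker inhibition is expected, though a result within the scatter would be no surprise. The expected change is a 1.8-fold higher number from compound 3 to compound 4 (0.26 log units; within the scatter) in this estimate. Compound 4 is estimated at 14000 nM, with an expected range from 5000 nM to 40000 nM.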

Compound 4, half-maximal inhibitory concentration: 14000 nM
Compound 4: middle estimate and measured number agree at the digits printed; low and high end bracket the measured number.
By their numbers in this assay, from the lowest: compound 2; then compounds 3 and 4 (each within the scatter of the next). At a limit, above all of these: compound 1.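

In this assay, putting hydrogen in place of the fluoro ortho to a nitro group gives a 1.8-fold higher number from compound 3 to compound 4 (0.26 log units; within the scatter), so the number does not clearly respond to this fluoro. Putting hydrogen in place of a nitro group on another aromatic carbon gives a 7.8-fold higher number from compound 2 to compound 4 (0.89 log units; beyond the scatter), so of the two single changes shown, only the nitro change clearly moves the number, towards weaker inhibition. Nothing at hand explains why either step has the size it does.

The compounds shown leave open how a chloro, methyl or amino group would read on the same aromatic carbon, where only fluoro and hydrogen appear so far. They also leave open whether both steps would hold if the two esters of the side chain were carboxylic acids.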